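The source may report more compounds than this note shows. Statements on the series, on what has been measured and on what is new or still open speak of the compounds shown alone.

In a functional assay on ECa-109 cells (Homo sapiens) for antiproliferative activity, read by MTT assay, with a stated time of 72 h (a lower number here means a stronger inhibitor, a higher number a weaker inhibitor), compound 1 `CCCSc1nc(N/N=C/c2ccc(C)cc2)c2nnn(Cc3ccccc3)c2n1` gives > 64000 nM as a limit of the assay and not as a number. This reading is the limit of > 64000 nM in this assay, at which 1 of the 3 values shown sits, and it gives compound 1 a limit in place of a defined position in the series.

Compound 2 `C#CCSc1nc(N/N=C(\C)c2ccccc2O)c2nnn(Cc3ccccc3)c2n1` gives 5250 nM and compound 3 `CCCSc1nc(N/N=C(\C)c2ccccc2O)c2nnn(Cc3ccc(F)cc3)c2n1` gives 21900 nM as measured numbers. Each of these differs from compound 1 in more than one place, so neither sizes a single change.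

Compound 4 `CCCSc1nc(N/N=C/c2ccc(N(C)C)cc2)c2nnn(Cc3ccccc3)c2n1` keeps the rest of compound 1 and changes one group: dimethylamino in place of methyl on an aromatic carbon (dimethylamino in place of methyl on an aromatic carbon, para to a large group). The same difference reads as 4-methylphenyl to 4-(dimethylamino)phenyl.

Among the measured compounds shown here, no measured pair differs in one place only, so this change has no direct precedent in this assay and the expectation is loose. A modest move toward stronger inhibition is expected, resting only on compound 3 at 21900 nM and compound 2 at 5250 nM giving measurable numbers. For the measured compounds named here, compound 4 may also return only a limit, which would show no defined step.

The estimated step is an at least 1.8-fold lower number from compound 1 to compound 4 (0.26 log units; that floor lies within the scatter) on present evidence. For compound 4 the value is expected at 35000 nM within an estimated range of 10000 nM to 90000 nM as a working figure.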

Compound 4, half-maximal inhibitory concentration: 20000 nM
For compound 4 the middle estimate is 1.8-fold (0.24 log units) above the measured one; low and high end bracket the measured number.
By their numbers in this assay, from the lowest: compound 2; then compounds 4 and 3 (each within the scatter of the next). At a limit, above all of these: compound 1.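

Among the compounds shown here, the change from methyl to dimethylamino on an aromatic carbon, para to a large group, gives the first step that can be read at a single place: an at least 3.2-fold lower number from compound 1 to compound 4 (0.50 log units; beyond the scatter) in this assay. This position is therefore not indifferent, since this one change, with the rest of compound 1 kept, brings compound 4 to a measured number, 20000 nM, which compound 2 and compound 3 could not show because each differs from compound 1 in more than one place. The reading for compound 1 is a limit and not a number, so the step is only a floor and its full size stays undefined: the limit of > 64000 nM in this assay, at which 1 of the 4 values shown sits.

From the compounds shown here alone, whether the gain is particular to dimethylamino or would also follow from another group at this place, such as methoxy, a primary amine or a carboxylic acid, remains open. Going by these compounds, compound 2 and compound 3 differ from compound 4 in more than one place, so steps to them cannot be read, and whether the same change would hold with the other parts of those compounds also remains open.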